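The source may hold more compounds than are shown below. What is called first, only, known or untested is meant among the compounds shown, and "the series" means these compounds.

Measured so far:
- Compound 1 `Cc1ccc(-c2noc(C3CCc4c(nnn4C(C)(C)C)C3)n2)cn1`: 1580 nM
- Compound 2 `CC(C)Cc1noc(C2CCc3c(nnn3C(C)(C)C)C2)n1`: 1000 nM

In a functional assay on U2OS cells for positive allosteric modulation of metabotropic glutamate receptor 5 (Homo sapiens), read by calcium flux, in the presence of a further agent that is not named here (on this read-out higher numbers stand for an effect only at larger amounts of compound and lower numbers for an effect already at smaller amounts), compound 2 gives 1000 nM, the lower of the two numbers, while compound 1 gives 1580 nM. For the measured compounds named here, the only step so far, a 1.6-fold lower number from compound 1 to compound 2 (0.20 log units; within the scatter), is within the scatter, so the two compounds cannot be told apart on this read-out.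

Compound 3 `CC(C)(C)n1nnc2c1CCC(c1nc(C3CCCCC3)no1)C2` keeps the shared core and changes the side group once more: cyclohexyl in place of isobutyl on an aromatic carbon. Going by the values given here, the single step that bears on it, a 1.6-fold lower number from compound 1 to compound 2 (0.20 log units; within the scatter), replaced an aromatic ring with a small branched chain at the same position and moved the number by an amount inside the scatter. Among the compounds with values here, the present change, a chain giving way to a saturated ring, has no direct precedent here, and nothing in the data points to a large move in either direction. The expected step is no change at the digits printed from compound 2 to compound 3 (within the scatter), none beyond the scatter. Compound 3 is therefore estimated at 1000 nM, with a range from 350 nM to 3000 nM.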

Compound 3, half-maximal effective concentration: 200 nM
Beside the measured number, compound 3's estimate is 5.0-fold (0.70 log units) above it, and the stated range ends above it.
By their numbers in this assay, from the lowest: compound 3; then compounds 2 and 1 (each within the scatter of the next).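

In this assay, for the compounds shown here, the aromatic carbon between two ring nitrogen atoms now proves sensitive to the group it carries: swapping a branched chain for a saturated ring gives a 5.0-fold lower number from compound 2 to compound 3 (0.70 log units; beyond the scatter), the first step here beyond the scatter. The same ring also compares favourably with the substituted aromatic ring, with a 7.9-fold lower number from compound 1 to compound 3 (0.90 log units; beyond the scatter), so the two earlier groups, which could not be told apart, both give way to cyclohexyl on this read-out. Nothing available here explains this shift.

Still open, from the compounds shown here alone, is whether the ring itself or the larger number of carbon atoms accounts for the step. A straight hexyl chain, which has no ring, and a cyclopentyl ring, which is smaller, could help separate the two, while a piperidine ring would show how a ring amine fares at this position.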